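The source may report more compounds than this note shows. Statements on the series, on what has been measured and on what is new or still open speak of the compounds shown alone.

Measured so far in a functional assay on NCI-H460 cells (Homo sapiens) for cytotoxicity; on this read-out lower numbers stand for stronger inhibition and higher numbers for weaker inhibition:
- Compound 1 `CS(=O)(=O)c1ccc2nc(NC(=O)CCCCC(=O)NO)sc2c1`: > 30 ug/mL (a limit of the assay)
- Compound 2 `Cc1ccc2nc(NC(=O)CCCCCCC(=O)NO)sc2c1`: 0.84 ug/mL

Among the measured compounds shown here, compound 2 holds the only actual number in this assay, since the other reading is a limit. Compound 3 (`Cc1ccc2nc(NC(=O)CCCCC(=O)NO)sc2c1`) departs from compound 2 through hydroxycarbamoyl in place of 2-(hydroxycarbamoyl)ethyl on a saturated chain carbon, four bonds along the chain from a carbonyl carbon.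

For the measured compounds named here, no measured step shows what such a change does. Compound 1 stands at the limit of > 30 ug/mL in this assay, at which 1 of the 2 values shown sits, and this is only a limit. That reading leans the expectation towards weaker inhibition, starting from compound 2 at 0.84 ug/mL. The expected size is a 6.0-fold higher number from compound 2 to compound 3 (0.77 log units; beyond the scatter), a move beyond the scatter, though loosely grounded. For compound 3 the estimated value is 5 ug/mL, with an expected range of 1.5 ug/mL to 25 ug/mL.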

Compound 3, half-maximal inhibitory concentration: 11 ug/mL
The estimate for compound 3 lay 2.2-fold (0.34 log units) below the measured number; measured number inside the range.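

In this assay, the change to hydroxycarbamoyl in place of 2-(hydroxycarbamoyl)ethyl, on a saturated chain carbon, four bonds along the chain from a carbonyl carbon, gives a 13-fold higher number from compound 2 to compound 3 (1.12 log units; beyond the scatter), so the shorter chain carries a large cost with the methyl group kept in place. The new compound also opens a second comparison, with methyl in place of methylsulfonyl on an aromatic carbon: an at least 2.7-fold lower number from compound 1 to compound 3 (0.43 log units; beyond the scatter). That step gives only a minimum size, as the reading for compound 1 is a limit of the assay and not a number: the limit of > 30 ug/mL in this assay, at which 1 of the 3 values shown sits.

On these data alone, it remains open whether a longer chain than that of compound 2 would continue this trend. Also open, as far as these compounds go, is how a carboxylic acid in place of the hydroxycarbamoyl end, or an amine in place of methyl on the aromatic carbon, would read.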